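Swapping a Thiophene Carbonyl for a Bromophenyl One

The source may hold more compounds than are shown below. What is called first, only, known or untested is meant among the compounds shown, and "the series" means these compounds.

Of the compounds shown here, two have so far been measured in an assay on isolated protein for inhibition of aldehyde dehydrogenase 1A1 (Homo sapiens), read by spectrophotometry, tested at 10 uM; on this read-out lower numbers stand for less inhibition and higher numbers for more inhibition at the one concentration tested (going by the name of the read-out). Compound 1 `Cc1cccc(Cn2c(OC3CCN(C(=O)c4ccco4)CC3)nc3ccccc32)c1` gives 68.3%, and compound 2 `Cc1cccc(Cn2c(CN3CCN(C(=O)c4cccs4)CC3)nc3ccccc32)c1` gives 60.8%. Compound 2 holds the lower of the two numbers, yet its gap to compound 1 lies within the scatter of the method. Compound 3 `Cc1cccc(Cn2c(CN3CCN(C(=O)c4ccc(Br)cc4)CC3)nc3ccccc32)c1` has not been measured. It differs from compound 2 by 4-bromophenyl in place of thiophen-2-yl on a carbonyl carbon. Going by the values given here, no measured pair shows this kind of change, so there is nothing to read a direction from. The change is expected to stay within the scatter, with an expected step of a number 1.2 percentage points higher from compound 2 to compound 3 (within the scatter). Compound 3 is estimated at 62%, between 40% and 82%.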

Compound 3, a percentage reported as inhibition, at one concentration (the size of the read-out at that concentration, not a potency): 25.8%
For compound 3 the middle estimate is 36.2 percentage points above the measured one, outside the stated range (below it).
By their numbers in this assay, from the lowest: compound 3; then compounds 2 and 1 (each within the scatter of the next).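

Putting 4-bromophenyl in place of thiophen-2-yl on this carbonyl carbon gives a number 35 percentage points lower from compound 2 to compound 3 (beyond the scatter) in this assay. This is the first step beyond the scatter among these compounds, so the read-out clearly responds to what sits on this carbonyl carbon. Nothing available explains why these two groups differ.

The compounds shown do not separate the effect of the bromine from that of the six-membered ring. Plain phenyl, which has no bromine, is the group that could tell the two apart.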